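Methyl for Fluoro on the Amide Aryl Ring

This account rests on a few compounds, and the source may have more. Where it says the series, first, only, none or still open, it means among the compounds named here.

Of the compounds shown here, two have been measured so far. Compound 1, with the structure `O=C(Nc1ccc(F)cc1)OCC1(C2CC2)OC(=O)Nc2ccc(Cl)cc21`, gives 1410 nM in an assay for inhibition of very long chain fatty acid elongase 6 (Homo sapiens); a higher number here means a weaker inhibitor, a lower number a stronger inhibitor. Compound 2, with the structure `O=C1Nc2ccc(Cl)cc2C(CNC(=O)c2ccccc2F)(C(F)(F)F)O1`, gives 539 nM in this assay. Compound 2 therefore holds the lower of the two numbers; the gap to compound 1 is beyond the usual scatter of repeated measurements, so compound 2 counts as the stronger inhibitor of the pair.

Compound 3, with the structure `Cc1ccccc1C(=O)NCC1(C(F)(F)F)OC(=O)Nc2ccc(Cl)cc21`, has not been measured. It differs from compound 2 in a single spot: methyl in place of fluoro on an aromatic carbon. Going by the values given here, the two measured compounds differ from each other in several places at once, so no step between them isolates what this kind of exchange does. With nothing in the data pointing one way or the other, the expectation for compound 3 is a step from compound 2 that stays within the scatter, namely a 1.1-fold higher number from compound 2 to compound 3 (0.05 log units; within the scatter). On that basis compound 3 is estimated at 600 nM in this assay, with a range from 250 nM to 1500 nM.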

Compound 3, half-maximal inhibitory concentration: 971 nM
Compound 3: middle estimate off by 1.6-fold (0.21 log units), on the low side; the measured number falls inside the stated range.
By their numbers in this assay, from the lowest: compounds 2, 3 and 1 (each within the scatter of the next, the first and the last beyond it).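

In this assay, going by these compounds alone, the exchange gives the first step in this set that isolates a single place: a 1.8-fold higher number from compound 2 to compound 3 (0.26 log units; within the scatter). Within the data shown here, at this aromatic carbon, ortho to a large group, 2-fluorophenyl and 2-methylphenyl therefore cannot be told apart in this assay, although the groups that leave and enter are made of different atoms, and this one step is the only reading so far of what a substituent at this place does. Nothing measured here speaks to what lies behind the step, or to why it is of this size.

The compounds shown leave open how a plain phenyl would compare, and whether a methoxy group, a chlorine or an amine at the same carbon would stay within the scatter of these two or move the number clearly in either direction. They also leave open what the trifluoromethyl group contributes relative to the cyclopropyl group of compound 1, as that compound differs from the others in several places at once and its steps cannot be read.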